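Notes on the step to compound 4

The source may hold more compounds than are shown below. What is called first, only, known or untested is meant among the compounds shown, and "the series" means these compounds.

Values in a functional assay on U-251 cells (Homo sapiens) for inhibition, read by sulforhodamine B assay, with a stated time of 48 h; a lower number here means a stronger inhibitor, a higher number a weaker inhibitor:
- compound 1 `COc1ccc2c(c1)[n+]([O-])c(C(=O)N=[N+]=[N-])c(C)[n+]2[O-]`: > 10 ug/mL (a limit)
- compound 2 `COc1ccc(NC(=O)Nc2c(C)[n+]([O-])c3ccc(Cl)cc3[n+]2[O-])cc1`: > 10 ug/mL (a limit)
- compound 3 `COc1ccc(NC(=O)Nc2c(C)[n+]([O-])c3ccc(OC)cc3[n+]2[O-])cc1`: > 10 ug/mL (a limit)

Compound 3 stands at > 10 ug/mL in this assay, which is a limit and not a number. Among the compounds with values here, the other two compounds give only limits as well, so the series so far has one reading: the limit of > 10 ug/mL in this assay, at which 3 of the 3 values shown sit.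

Compound 4 `COc1ccc2c(c1)[n+]([O-])c(NC(=O)OC(C)C)c(C)[n+]2[O-]` is still to be measured. It differs from compound 3 as follows: isopropoxy in place of (4-methoxyphenyl)amino on a carbonyl carbon. In short, isopropoxy stands in place of (4-methoxyphenyl)amino on a carbonyl carbon, and the shared core is unchanged.

Within the data shown here, only one measured step bears on this, and it involves a different change: a step that the two limits leave unreadable from compound 2 to compound 3. Among the measured compounds shown here, it gives no size, and no measured step touches the carbonyl substituent. No step beyond the scatter is therefore expected in this assay, and no direction can be assigned. The expected step, with no firm direction behind it, is a step that the limit leaves unreadable from compound 3 to compound 4. A report as a limit again is the likeliest outcome.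

The estimate for compound 4 is 12 ug/mL, with an expected range from 3 ug/mL to 30 ug/mL.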

Compound 4, half-maximal inhibitory concentration: > 10 ug/mL
Compound 4 gave a limit, no number; the forecaster's own chance of this, stated with the estimate: 65%; the middle value does not contradict the limit.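

In this assay compound 4 gives > 10 ug/mL as a limit and not a number, so no new step can be read from compound 3 or compound 1 to compound 4. The compounds shown leave open whether isopropoxy or (4-methoxyphenyl)amino on the carbonyl carbon makes any difference to inhibition, and how large it would be.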